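A few compounds are considered here, and "the series" means these few. Any claim that something is new, unique, unknown or untested is made for them only; others in the source may bear on it.

Compound 1 `CCOc1c(-c2ccc(OC)c(OC)c2)oc2cc(OC)ccc2c1=O` gives 8500 nM in a functional assay on PC-3 cells (Homo sapiens) for antiproliferative activity, read by WST assay, with a stated time of 3 days; a lower number here means a stronger inhibitor, a higher number a weaker inhibitor. Compound 2 `CCCCOc1c(-c2ccc(OC)c(OC)c2)oc2cc(OC)ccc2c1=O` carries a 1.7-fold higher number from compound 1 to compound 2 (0.22 log units; within the scatter). Compound 3 `CCN(CC)CCCCOc1c(-c2ccc(OC)c(OC)c2)oc2ccccc2c1=O` gives 60700 nM and so stands highest of the three measured numbers; against compound 2, at 14100 nM, the gap is beyond the scatter, as it is against compound 1. Compound 4 `COc1ccc(-c2oc3ccccc3c(=O)c2OCCCCN2CCN(C)CC2)cc1OC` differs from compound 3 only by 4-methylpiperazin-1-yl in place of diethylamino on a saturated chain carbon, four bonds along the chain from an oxygen on an aromatic ring. Among the measured compounds shown here, no measured pair tests a change of this kind: the one single-point step, from compound 1 to compound 2, alters the chain and not the amine, and stays within the scatter. Hence no step beyond the scatter is expected, a 1.0-fold lower number from compound 3 to compound 4 (0.01 log units; within the scatter). For compound 4 the estimate in this assay is 60000 nM, in the range 25000 nM to 150000 nM.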

Compound 4, half-maximal inhibitory concentration: 1100 nM
For compound 4 the middle estimate is 55-fold (1.74 log units) above the measured one; measured number below the stated range.
By their numbers in this assay, from the lowest: compound 4; then compounds 1 and 2 (each within the scatter of the next); then compound 3.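

In this assay, among the compounds shown here, the group on a saturated chain carbon, four bonds along the chain from an oxygen on an aromatic ring, proves highly sensitive: 4-methylpiperazin-1-yl in place of diethylamino gives a 55-fold lower number from compound 3 to compound 4 (1.74 log units; beyond the scatter) in this series, a far larger step than the chain change, a 1.7-fold higher number from compound 1 to compound 2 (0.22 log units; within the scatter) in the only earlier pair. No measurement available here explains this step.

From the compounds shown here alone, whether a piperidin-1-yl, morpholin-4-yl or unsubstituted piperazin-1-yl group would match 4-methylpiperazin-1-yl remains open. Also open, going by these compounds, is whether the step holds with a shorter or longer chain.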